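Inactive chromone cinnamamides: a benzyl variant to come

A few compounds are considered here, and "the series" means these few. Any claim that something is new, unique, unknown or untested is made for them only; others in the source may bear on it.

Measured so far:
- compound 1 `O=C(/C=C/c1coc2cc(O)ccc2c1=O)NCc1ccccc1`
- compound 2 `COc1ccc2c(=O)c(/C=C/C(=O)Nc3ccccc3)coc2c1`
- compound 3 `COc1ccc(NC(=O)/C=C/c2coc3cc(O)ccc3c2=O)cc1`

In a functional assay on HeLa cells (Homo sapiens) for inhibition, read by MTT assay, with a stated time of 48 h (a lower number here means a stronger inhibitor, a higher number a weaker inhibitor), compound 1 gives only a limit, > 100000 nM. In this assay compound 2 likewise gives only a limit, > 100000 nM. Compound 3 too gives only a limit in this assay, > 100000 nM. For the measured compounds named here, compound 2 therefore stands at the limit together with the rest, as the limit of > 100000 nM in this assay, at which 3 of the 3 values shown sit, records, and the one direct comparison, a step that the two limits leave unreadable from compound 1 to compound 3, cannot be read.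

Compound 4 `COc1ccc(CNC(=O)/C=C/c2coc3cc(OC)ccc3c2=O)cc1` carries 4-methoxybenzyl in place of phenyl on an amide-type nitrogen. Going by the values given here, no measured step speaks to this change, and nothing among the three compounds shows a departure from the limit. Compound 4 is accordingly expected to stay weak, with an estimated 150000 nM (range 40000 nM to 600000 nM); the expected step that the limit leaves unreadable from compound 2 to compound 4 amounts to none beyond the scatter.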

Compound 4, half-maximal inhibitory concentration: > 100000 nM
Compound 4: a limit, no number; the forecaster's own chance of this, stated with the estimate: 85%; the middle value is on the limit's open side.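

For the compounds shown here, compound 2 and compound 4 both give only a limit, so no step between them can be read. The compounds shown leave open which change on the amide-type nitrogen or the shared core, if any, would give a measurable value.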